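Phenol methylation on the dinitrate ester of compound 2

The source may hold more compounds than are shown below. What is called first, only, known or untested is meant among the compounds shown, and "the series" means these compounds.

Measured so far in a functional assay on HOP-62 cells (Homo sapiens) for cytotoxicity, read by resazurin assay, with a stated time of 72 h; on this read-out higher numbers stand for weaker inhibition and lower numbers for stronger inhibition:
- compound 1, `COc1cc(/C=C/C(=O)OC(C)CCOc2no[n+]([O-])c2S(=O)(=O)c2ccccc2)ccc1O`: 420 nM
- compound 2, `O=C(/C=C/c1ccc(OCCCCCCO[N+](=O)[O-])c(O)c1)OCCCCCCO[N+](=O)[O-]`: a limit, > 50000 nM

Among the compounds with values here, compound 1 is the only member of the pair with a numerical value in this assay. For compound 2 this assay gives no number but only a limit, > 50000 nM. That limit is where compound 2 stands on the numbers shown: the limit of > 50000 nM in this assay, at which 1 of the 2 values shown sits. Within the data shown here, compound 2 and compound 1 differ in several places at once, so the two values show only that compound 1 inhibits and compound 2 does not reach the scale; no single step can be read from them.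

Compound 3, `COc1cc(/C=C/C(=O)OCCCCCCO[N+](=O)[O-])ccc1OCCCCCCO[N+](=O)[O-]`, is not yet measured. It differs from compound 2 in one place: methyl in place of hydrogen on an oxygen on an aromatic ring. Compound 2 sits at the limit, and the change is small, so no step beyond the scatter is expected; the step from compound 2 to compound 3 that the estimate means is a number no higher from compound 2 to compound 3 (the limit leaves the size open). Compound 3 is expected to give about 50000 nM in this assay, within 15000 nM to 150000 nM, most likely again as a limit.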

Compound 3, half-maximal inhibitory concentration: > 50000 nM
Compound 3: a limit, no number (the forecaster's own chance of this, stated with the estimate: 70%); the middle value sits exactly at the limit.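

No step from hydroxy to methoxy can be read between compound 2 and compound 3, because both stand at the same limit rather than at a number: the limit of > 50000 nM in this assay, at which 2 of the 3 values shown sit.

The compounds shown leave open whether this change matters in a compound with a numerical value, and which of the several differences separates compound 1 from compound 2.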